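Swapping a saturated ring for a methylated benzyl group

A few compounds are considered here, and "the series" means these few. Any claim that something is new, unique, unknown or untested is made for them only; others in the source may bear on it.

Measured compounds:
- compound 1, `CNC(=O)c1cc(C(=O)NC2CCC2)cn(Cc2ccccn2)c1=O`, 2.2
- compound 2, `CNC(=O)c1cc(C(=O)NC2CC2)cn(CC2CCOCC2)c1=O`, 1.5
- compound 3, `CNC(=O)c1cc(C(N)=O)cn(Cc2ccccc2)c1=O`, 2

Of the three numbers in a physicochemical assay for lipophilicity, at pH 7.4 (a lower number here means a more polar compound, a higher number a more lipophilic compound), compound 2 sits lowest, beyond the scatter from both others: compound 3 lies higher and compound 1 higher still. Compound 4, `CNC(=O)c1cc(C(=O)NC2CC2)cn(Cc2ccc(C)cc2)c1=O`, has not yet been measured in this assay. It differs from compound 2 in one place: 4-methylphenyl in place of oxan-4-yl on a saturated chain carbon bound to an aromatic nitrogen. Within the data shown here, none of the measured pairs differs in only one place, so no measured step is available to anchor this change. Still, the compound that carries a benzyl group where compound 4 carries 4-methylbenzyl, compound 3, gives 2, and compound 1 gives 2.2, both above compound 2. The expected step from compound 2 to compound 4 is therefore upward, a number 1.40 log units higher from compound 2 to compound 4 (beyond the scatter), well beyond the scatter. Compound 4 is estimated to reach 2.9, within a range from 2.3 to 3.5.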

Compound 4, distribution coefficient: 3.5
Estimate against measurement, compound 4: 0.60 log units below; the range from low to high includes it.
By their numbers in this assay, from the lowest: compound 2; then compounds 3 and 1 (each within the scatter of the next); then compound 4.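

In this assay, putting 4-methylphenyl in place of oxan-4-yl on a saturated chain carbon bound to an aromatic nitrogen gives a number 2.00 log units higher from compound 2 to compound 4 (beyond the scatter). Among these compounds, this is the first measured pair that differs in only one place, and it shows that this position alone can move the number by a large step while the rest of the molecule stays the same. Nothing shown accounts for the size of this step.

The change replaces a non-aromatic ring with one hetero atom by an aromatic ring of carbon only and also adds a methyl group, and these two parts cannot be separated here, as compound 3 carries plain benzyl but also differs at the other amide. From the compounds shown here alone, how a cyclohexyl ring, or a benzyl group bearing an amine or a carboxylic acid, would read at this position remains open.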